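The source may report more compounds than this note shows. Statements on the series, on what has been measured and on what is new or still open speak of the compounds shown alone.

Measured compounds in an assay on HEK293 cells for displacement of a labelled ligand from Melanocortin receptor 4 (Homo sapiens); on this read-out lower numbers stand for stronger inhibition and higher numbers for weaker inhibition:
- compound 1, `CC(C)C[C@H](N)c1cc(C(F)(F)F)ccc1N1CCN(C(=O)CCc2ccccc2Cl)CC1`: 1700 nM
- compound 2, `COc1ccc(CCC(=O)N2CCN(c3ccc(C(F)(F)F)cc3[C@@H](N)CC(C)C)CC2)cc1`: 350 nM
- compound 3, `COc1cc(OC)c(OC)cc1CCC(=O)N1CCN(c2ccc(C(F)(F)F)cc2[C@@H](N)CC(C)C)CC1`: 6100 nM

Compound 1 holds the second highest of the three numbers in this assay. The nearest value is that of compound 3, reached by a 3.6-fold higher number from compound 1 to compound 3 (0.55 log units; beyond the scatter); the furthest is that of compound 2, reached by a 4.9-fold lower number from compound 1 to compound 2 (0.69 log units; beyond the scatter). Between those two the gap is a 17-fold higher number from compound 2 to compound 3 (1.24 log units; beyond the scatter).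

Compound 4, `CC(C)C[C@H](N)c1cc(C(F)(F)F)ccc1N1CCN(C(=O)CCc2cccs2)CC1`, is not yet measured. It differs from compound 1 only at the aryl group on the chain: thiophen-2-yl in place of 2-chlorophenyl on a saturated chain carbon, two bonds along the chain from a carbonyl carbon.

For the measured compounds named here, the steps that bear on this change are the two from compound 1, since both replace the same 2-chlorophenyl at the same place on the chain. They run in opposite directions and both are modest in size: one to a lower number, one to a higher number. Going by the values given here, neither introduces thiophen-2-yl, so there is no direct precedent for this ring, and nothing in the three measured compounds points to a large step in either direction. The working expectation is therefore a step of modest size at most, with the direction uncertain and a slight lean toward no change or a somewhat higher number. Compound 4 is estimated at 2000 nM, within 600 nM to 6500 nM, which means an expected 1.2-fold higher number from compound 1 to compound 4 (0.07 log units; within the scatter).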

Compound 4, inhibition constant: 4600 nM
Compound 4: the middle estimate sits 2.3-fold (0.36 log units) below what was measured, within the range that was stated.
By their numbers in this assay, from the lowest: compound 2; then compound 1; then compounds 4 and 3 (each within the scatter of the next).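

In this assay, for the compounds shown here, thiophen-2-yl on a saturated chain carbon, two bonds along the chain from a carbonyl carbon, gives the first direct reading for a five-membered ring with a hetero atom at this position (a 2.7-fold higher number from compound 1 to compound 4 (0.43 log units; beyond the scatter)), and the number moves the same way as with 2,4,5-trimethoxyphenyl. The two rings differ in size and substitution yet cannot be separated here (a 1.3-fold lower number from compound 3 to compound 4 (0.12 log units; within the scatter)), whereas 4-methoxyphenyl stands well apart from thiophen-2-yl (a 13-fold higher number from compound 2 to compound 4 (1.12 log units; beyond the scatter)), so compound 2 is the only one of the three replacements for 2-chlorophenyl that gives a lower number than compound 1. No measurement at hand accounts for this ordering of the aryl groups.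

As far as these compounds go, how an unsubstituted phenyl ring or a furan ring would read on this chain remains open, and with it whether the lower number of compound 2 depends on its methoxy group. Also open, from the compounds shown here alone, is whether a longer chain between the carbonyl and the ring would keep the same ordering of these aryl groups.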